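Swapping Chloro for Methoxy on the Pendant Ring

The compounds below may be only part of what the source reports. "The series", "measured", "known", "first", "only" and "open" are said of these compounds alone.

Compound 1 `Cc1ccc2c(c1)C(=O)/C(=C/c1ccccc1)CN2CC(=O)O`: 4.23%
Compound 2 `COc1cccc(/C=C2\CN(CC(=O)O)c3ccc(C)cc3C2=O)c1`: 14.4%
Compound 3 `Cc1ccc2c(c1)C(=O)/C(=C/c1ccc(Cl)cc1)CN2CC(=O)O`: 20.7%

In an assay on HL-60 cells for inhibition of glutathione S-transferase P (Homo sapiens), read by spectrophotometry, tested at 20 uM (on this read-out higher numbers stand for more inhibition at the one concentration tested (going by the name of the read-out) and lower numbers for less inhibition), compound 3 gives 20.7%, the highest of the three numbers. The step of a number 16.5 percentage points higher from compound 1 to compound 3 (beyond the scatter) lies beyond the scatter, whereas a number 6.3 percentage points higher from compound 2 to compound 3 (within the scatter) lies within it, so compound 3 is not set apart from compound 2. Compound 4 `COc1ccc(/C=C2\CN(CC(=O)O)c3ccc(C)cc3C2=O)cc1` differs from compound 3 in one place: methoxy in place of chloro on an aromatic carbon. Among the measured compounds shown here, the steps that bear on this are a number 10.2 percentage points higher from compound 1 to compound 2 (beyond the scatter) and a number 16.5 percentage points higher from compound 1 to compound 3 (beyond the scatter), both modest gains, and a number 6.3 percentage points higher from compound 2 to compound 3 (within the scatter), which is within the scatter. A step no larger than the scatter, if anything slightly downward, is therefore expected, a number 6.7 percentage points lower from compound 3 to compound 4 (within the scatter). Compound 4 is estimated at 14%, within a range from 4% to 26%.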

Compound 4, a percentage reported as inhibition, at one concentration (the size of the read-out at that concentration, not a potency): 17.5%
Beside the measured number, compound 4's estimate is 3.5 percentage points below it; measured number inside the range.
By their numbers in this assay, from the lowest: compound 1; then compounds 2, 4 and 3 (each within the scatter of the next).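

Methoxy on the aromatic carbon para to a large group also beats hydrogen (a number 13.3 percentage points higher from compound 1 to compound 4 (beyond the scatter)), so in this assay this position now shows a modest gain with either chloro or methoxy. The two groups cannot be told apart there (a number 3.2 percentage points lower from compound 3 to compound 4 (within the scatter)), and 4-methoxyphenyl cannot be told apart from 3-methoxyphenyl (a number 3.1 percentage points higher from compound 2 to compound 4 (within the scatter)). No measurement here accounts for these numbers.

Still open, as far as these compounds go, is whether an amine or a longer alkoxy chain at this position would separate from chloro and methoxy. Also open, from the compounds shown here alone, is how 3-chlorophenyl would compare with 4-chlorophenyl.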